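This account rests on a few compounds, and the source may have more. Where it says the series, first, only, none or still open, it means among the compounds named here.

Compound 1 `CCC(=O)Oc1cccc2ccc(/C=C/c3ccccc3[N+](=O)[O-])nc12` gives 6300 nM
Compound 2 `O=C(/C=C/c1ccc([N+](=O)[O-])o1)c1ccc(Br)cc1` gives 2700 nM
Compound 3 `CCCCc1ccc(C(=O)/C=C/c2ccc([N+](=O)[O-])o2)cc1` gives 1700 nM

These values come from a functional assay on C6 cells (Rattus norvegicus) for inhibition, read by sulforhodamine B assay, with a stated time of 72 h; a higher number here means that more compound is needed for the effect, a lower number that less compound is needed. There, compound 3 cannot be told apart from compound 2, while compound 1 carries the higher number, beyond the scatter. Compound 4 `O=C(/C=C/c1ccc([N+](=O)[O-])o1)c1ccc(-c2ccccc2)cc1` has phenyl in place of butyl on an aromatic carbon of compound 3 (phenyl in place of butyl on an aromatic carbon). Among the measured compounds shown here, one measured step bears on this position, a 1.6-fold lower number from compound 2 to compound 3 (0.20 log units; within the scatter), and it stays within the scatter. From the compounds shown here alone, no step beyond the scatter is therefore expected in this assay, although phenyl itself is untested here. The expected step is a 1.2-fold higher number from compound 3 to compound 4 (0.07 log units; within the scatter). Compound 4 is estimated at 2000 nM, with an expected range of 800 nM to 5000 nM.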

Compound 4, half-maximal effective concentration: 17700 nM
For compound 4 the middle estimate is 8.9-fold (0.95 log units) below the measured one, and the stated range ends below it.
By their numbers in this assay, from the lowest: compounds 3 and 2 (each within the scatter of the next); then compound 1; then compound 4.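

In this assay this position turns out not to be indifferent to its group: phenyl in place of butyl gives a 10-fold higher number from compound 3 to compound 4 (1.02 log units; beyond the scatter), and phenyl in place of bromo gives a 6.6-fold higher number from compound 2 to compound 4 (0.82 log units; beyond the scatter). Bromo and butyl had stayed within the scatter of each other, so the earlier compounds gave no sign that a change here could move the number this far. Nothing measured here accounts for the jump.

From the compounds shown here alone, it remains open whether a cyclohexyl group or a longer chain on this aromatic carbon would stay with butyl and bromo or go with phenyl. The same holds for an amine or a carboxylic acid there.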